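A few compounds are considered here, and "the series" means these few. Any claim that something is new, unique, unknown or untested is made for them only; others in the source may bear on it.

Measured compounds:
- Compound 1, `CC(C)(C)C/N=C(\NC#N)Nc1ccncc1`: 5 mg/kg
- Compound 2, `CCC(/N=C(\NC#N)Nc1ccncc1)C(C)C`: 5 mg/kg
- Compound 3, `CCC(C)(CC)/N=C(\NC#N)Nc1ccncc1`: 0.5 mg/kg

In a functional assay on the whole organism (blood, strain Wistar-Okamoto) with Rattus norvegicus as the target, with a stated time of 5 days (a higher number here means that more compound is needed for the effect, a lower number that less compound is needed), compound 3 gives the lowest number of the three, with a 10-fold lower number from compound 1 to compound 3 (1.00 log units; beyond the scatter) and a 10-fold lower number from compound 2 to compound 3 (1.00 log units; beyond the scatter) setting it apart from the other two, while no change at the digits printed from compound 1 to compound 2 (within the scatter) separates nothing. Compound 4, `N#CN/C(=N\c1ccccc1)Nc1ccncc1`, differs from compound 3 in one place: phenyl in place of 1-ethyl-1-methylpropyl on a double-bonded nitrogen. Within the data shown here, no measured step exchanges an alkyl group for an aromatic ring on that nitrogen, so the comparison rests only on the observation that the single branched group of compound 3 gave a lower number than those of compounds 1 and 2. Compound 4 is therefore expected to need more compound than compound 3, with a step of about a 10-fold higher number from compound 3 to compound 4 (1.00 log units; beyond the scatter) in this assay. The estimate for compound 4 is 5 mg/kg, within a range from 1 mg/kg to 25 mg/kg.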

Compound 4, minimum effective dose: 50 mg/kg
For compound 4 the middle estimate is 10-fold (1.00 log units) below the measured one, and the stated range ends below it.
By their numbers in this assay, from the lowest: compound 3; then compounds 1 and 2 (each within the scatter of the next); then compound 4.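

In this assay phenyl is the only aromatic ring on the double-bonded nitrogen, and it gives the highest number of the series, with a 100-fold higher number from compound 3 to compound 4 (2.00 log units; beyond the scatter) against 1-ethyl-1-methylpropyl. The two other alkyl groups also stand clearly lower than phenyl, with a 10-fold higher number from compound 2 to compound 4 (1.00 log units; beyond the scatter) for 1-isopropylpropyl and a 10-fold higher number from compound 1 to compound 4 (1.00 log units; beyond the scatter) for neopentyl as the steps. No measurement at hand accounts for this gap between the ring and the alkyl groups. Going by these compounds, whether cyclohexyl, or a phenyl carrying a methoxy group, would fall with the alkyl groups or with phenyl stays open.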